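This account rests on a few compounds, and the source may have more. Where it says the series, first, only, none or still open, it means among the compounds named here.

Measured in a functional assay on HCT-116 cells (Homo sapiens) for cytotoxicity, read by sulforhodamine B assay, with a stated time of 48 h; on this read-out higher numbers stand for weaker inhibition and lower numbers for stronger inhibition:
- compound 1 `CC(=O)n1nc(NC(=O)c2ccccc2)c2c1CN(C(=O)C1CCC(C)CC1)C2` gives 12200 nM
- compound 2 `CC(=O)n1nc(NC(=O)c2ccccc2)c2c1CN(C(=O)c1ccc(-c3ccccc3)cc1)C2` gives > 90000 nM, a limit of the assay and not a number
- compound 3 `CC(=O)n1nc(NC(=O)c2ccccc2)c2c1CN(C(=O)c1cccc(Cl)c1)C2` gives 17400 nM

Compound 3 stands level with compound 1, its nearest measured neighbour: a 1.4-fold higher number from compound 1 to compound 3 (0.15 log units; within the scatter). Compound 4 `CC(=O)n1nc(NC(=O)c2ccccc2)c2c1CN(C(=O)c1ccc([N+](=O)[O-])cc1)C2` carries 4-nitrophenyl in place of 3-chlorophenyl on a carbonyl carbon. Within the data shown here, the one measured step at this place is that small one from compound 1 to compound 3. Compound 2, changed at the same place, reads > 90000 nM, a limit, so the expected range stays wide on the upper side. The step expected in this assay is a 1.1-fold higher number from compound 3 to compound 4 (0.06 log units; within the scatter), nothing beyond the scatter. For compound 4 the estimated value is 20000 nM, with an expected range from 7000 nM to 60000 nM.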

Compound 4, half-maximal inhibitory concentration: 16200 nM
Compound 4: middle estimate off by 1.2-fold (0.09 log units), on the high side, within the range that was stated.
By their numbers in this assay, from the lowest: compounds 1, 4 and 3 (each within the scatter of the next). At a limit, above all of these: compound 2.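

In this assay, 4-nitrophenyl on the carbonyl carbon gives no separation from either earlier group: a 1.1-fold lower number from compound 3 to compound 4 (0.03 log units; within the scatter) and a 1.3-fold higher number from compound 1 to compound 4 (0.12 log units; within the scatter). The 4-methylcyclohexyl, 3-chlorophenyl and 4-nitrophenyl compounds therefore all lie within the scatter of one another. The only step beyond the scatter is an at least 5.5-fold lower number from compound 2 to compound 4 (0.74 log units; beyond the scatter), with nitro in place of phenyl on an aromatic carbon, and it starts from compound 2, whose reading is a limit of the assay and not a number: the limit of > 90000 nM in this assay, at which 1 of the 4 values shown sits.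

Going by these compounds, whether an amine or a carboxylic acid in place of nitro would read differently stays open. The compounds shown also leave open what a change elsewhere on the shared core would do.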